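This account rests on a few compounds, and the source may have more. Where it says the series, first, only, none or still open, it means among the compounds named here.

Measured compounds:
- compound 1, `CCOC(CCn1c(Cc2nn(C)c(=O)c3ccccc23)nnc1SCC(=O)Nc1ccc(Cl)cc1Cl)OCC`: > 30000 nM
- compound 2, `Cn1nc(Cc2nnc(SCCCCCCCC(=O)Nc3ccc(Cl)cc3Cl)n2CCC=O)c2ccccc2c1=O`: 710 nM

The study is read in an assay on NK92 cells for inhibition of interleukin-15 (Homo sapiens), read by AlphaScreen, with stated times of 30 min and 1 h; on this read-out higher numbers stand for weaker inhibition and lower numbers for stronger inhibition. Compound 1 is reported only as a limit of the assay, > 30000 nM, and not as a number. Going by the values given here, compound 2, with 710 nM, thus holds the only numerical value among the two measured compounds. The entry of compound 1 sits at the limit of > 30000 nM in this assay, at which 1 of the 2 values shown sits, a limit and not a number. Hence no measured step can be drawn between the two measured compounds.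

The unmeasured compound is compound 3, `Cn1nc(Cc2nnc(SCCCCCCCC(=O)Nc3ccc(Cl)cc3Cl)n2CCC(=O)O)c2ccccc2c1=O`. It differs from compound 2 in one place: hydroxy in place of hydrogen on a carbonyl carbon, the formyl end of the chain on the core nitrogen becoming a carboxy group. Among the compounds with values here, no pair of measured compounds shows this change, so its size is not known here.

For compound 3 the expectation is a modest loss of inhibition, a 2.1-fold higher number from compound 2 to compound 3 (0.32 log units; beyond the scatter), close to the edge of the usual scatter rather than clearly beyond it. Compound 3 is therefore estimated at 1500 nM, within 400 nM to 6000 nM.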

Compound 3, half-maximal inhibitory concentration: 9500 nM
The estimate for compound 3 lay 6.3-fold (0.80 log units) below the measured number; measured number outside the range, above it.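

In this assay, going by these compounds alone, the change from 2-formylethyl to 2-carboxyethyl, hydroxy in place of hydrogen on a carbonyl carbon whose other neighbour is a saturated chain carbon, gives a 13-fold higher number from compound 2 to compound 3 (1.13 log units; beyond the scatter) and is the first step that can be read in this set. It shows that this position is not indifferent to what stands at the end of the chain: a change of one heavy atom, with the rest of compound 2 left as it stands, is enough to give a large step in this assay. The compounds shown offer no measured reason for the size of this step.

Steps to compound 1 cannot be read, since that compound differs from the others in more than one place and its entry is a limit. Open too, going by these compounds, is where a hydroxymethyl group, a primary amide or a methyl ester at this chain end would fall relative to compound 2 and compound 3, and whether a longer chain carrying the carboxy group would give a step of the same size.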